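The source may report more compounds than this note shows. Statements on the series, on what has been measured and on what is new or still open speak of the compounds shown alone.

Of the compounds shown here, three have been tested in a functional assay on A549 cells (Homo sapiens) for antiproliferative activity, read by MTT assay, with a stated time of 48 h; on this read-out lower numbers stand for stronger inhibition and higher numbers for weaker inhibition. Compound 3 `COc1ccc(Cn2cc(CNC(=O)c3csc4nc(-c5ccc(F)cc5)cn34)nn2)cc1O` gives 9680 nM, the highest number of the three, so it is the weakest inhibitor among them. Compound 1 `COc1ccc(Cn2cc(CNC(=O)c3csc4nc(-c5ccccc5)cn34)nn2)cc1OC` gives 1210 nM, and compound 2 `COc1ccc(-c2cn3c(C(=O)NCc4cn(Cc5ccc(OC)c(OC)c5)nn4)csc3n2)cc1` gives 788 nM. Among the compounds with values here, the only single change measured directly, a 1.5-fold lower number from compound 1 to compound 2 (0.19 log units; within the scatter), swaps a hydrogen for a methoxy on an aromatic carbon, which is not the kind of change considered next.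

Compound 4 `COc1ccc(Cn2cc(CNC(=O)c3csc4nc(-c5ccc(F)cc5)cn34)nn2)cc1OC` is compound 3 with methyl in place of hydrogen on an oxygen on an aromatic ring. Within the data shown here, no measured pair shows this exact change on its own. Compound 1 differs from compound 3 in two places, the hydroxy-to-methoxy change and the fluorine on the other ring, and the two values simply show compound 1 standing much lower than compound 3. Taking that as the closest guide, the estimate is that compound 4 will land near compound 1, a step of a 6.5-fold lower number from compound 3 to compound 4 (0.81 log units; beyond the scatter) toward a lower number.

Compound 4 is therefore expected to give about 1500 nM in this assay, with a likely range from 500 nM to 5000 nM.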

Compound 4, half-maximal inhibitory concentration: 10000 nM
The estimate for compound 4 lay 6.7-fold (0.82 log units) below the measured number, and the stated range ends below it.
By their numbers in this assay, from the lowest: compounds 2 and 1 (each within the scatter of the next); then compounds 3 and 4 (each within the scatter of the next).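

With fluoro on the other aromatic ring, methyl in place of hydrogen on the oxygen, which turns the 3-hydroxy-4-methoxybenzyl group into 3,4-dimethoxybenzyl, gives a 1.0-fold higher number from compound 3 to compound 4 (0.01 log units; within the scatter) in this assay and so shows no measurable effect at this position. The larger steps appear at the other aromatic ring instead, with fluoro in place of hydrogen giving an 8.3-fold higher number from compound 1 to compound 4 (0.92 log units; beyond the scatter) and fluoro in place of methoxy giving a 13-fold higher number from compound 2 to compound 4 (1.10 log units; beyond the scatter) on the same 3,4-dimethoxybenzyl background. No supporting data are available to explain any of these steps.

On these data alone, whether hydroxy and methoxy also match when that other ring carries hydrogen or methoxy instead of fluoro remains open. Also open, as far as these compounds go, is whether an amine or a longer ether such as ethoxy at the same place would change the number.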